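The source may hold more compounds than are shown below. What is called first, only, known or untested is meant among the compounds shown, and "the series" means these compounds.

Series notes. In an ADME assay on RAW264.7 cells (Mus musculus) for cytotoxicity, read by MTT assay, with a stated time of 24 h, in the presence of a further agent that is not named here (on this read-out higher numbers stand for weaker inhibition and lower numbers for stronger inhibition), two compounds have results so far. Compound 1, `O=C1OC(Cc2nc(-c3ccc(Oc4ccccc4)cc3)no2)c2ccccc21`, gives > 40000 nM in this assay, which is a limit of the assay rather than a number. Compound 2, `COCCCCOc1ccc(C(O)C2OC(=O)c3c(OC)cc(OC)cc32)cc1`, likewise gives > 40000 nM in this assay, again a limit and not a number. Among the compounds with values here, compound 2 therefore stands at the limit, and so does the one other value shown: the limit of > 40000 nM in this assay, at which 2 of the 2 values shown sit. Within the data shown here, no step between two measured compounds is available, so nothing in the data so far shows how any single structural change moves this read-out.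

Compound 3, `COc1cc(OC)c2c(c1)C(C(O)c1ccc(OCc3ccc(OC(F)(F)F)cc3)cc1)OC2=O`, is the next compound to be measured in this assay. It differs from compound 2 by 4-(trifluoromethoxy)phenyl in place of 3-methoxypropyl on a saturated chain carbon bound to an oxygen on an aromatic ring. With both known values sitting at the limit, the change from compound 2 to compound 3 is expected to give no step beyond the scatter in this assay, and the most probable outcome is once more a limit. The step that this expectation means is a number no higher from compound 2 to compound 3 (the limit leaves the size open). Compound 3 is estimated at 40000 nM, with a range from 15000 nM to 100000 nM.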

Compound 3, half-maximal inhibitory concentration: > 40000 nM
Compound 3: only a limit was reported (the forecaster's own chance of this, stated with the estimate: 80%); the middle value sits exactly at the limit.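

No step can be read from compound 2 to compound 3 in this assay: both results are limits of the assay and not numbers. The compounds shown leave open whether 4-(trifluoromethoxy)phenyl in place of 3-methoxypropyl moves this read-out at all, and which structural change would bring a result off the limit: the limit of > 40000 nM in this assay, at which 3 of the 3 values shown sit.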